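This account rests on a few compounds, and the source may have more. Where it says the series, first, only, none or still open, it means among the compounds named here.

For the measured compounds named here, of the two compounds measured so far in an ADME assay on MT4 cells (Homo sapiens) for cytotoxicity, read by MTT assay (a lower number here means that less compound is tolerated, a higher number that more compound is tolerated), compound 2 `Cc1cc(/C=C/C#N)cc(C)c1Oc1ccnc(Nc2ccc(CN3CCN(S(=O)(=O)C(C)C)CC3)cc2)n1` gives 3810 nM, the lower of the two numbers, and compound 1 `CCS(=O)(=O)N1CCN(Cc2ccc(Nc3nccc(Oc4c(C)cc(/C=C/C#N)cc4C)n3)cc2)CC1` gives 4600 nM. The two differ in one place only: a 1.2-fold lower number from compound 1 to compound 2 (0.08 log units; within the scatter), so the numbers stand within the scatter of each other and no order can be read from them.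

Compound 3 `Cc1cc(/C=C/C#N)cc(C)c1Oc1ccnc(Nc2ccc(CN3CCN(S(=O)(=O)C4CC4)CC3)cc2)n1` has not yet been measured. It differs from compound 2 in one place: cyclopropyl in place of isopropyl on a sulfonyl sulfur. Going by the values given here, the only step known in this region of the structure is the one from compound 1 to compound 2, which stayed within the scatter, and the new change keeps the same number of carbon atoms on the sulfonyl sulfur. Among the compounds with values here, nothing measured so far points to a shift beyond the scatter in this assay.

Compound 3 is therefore expected to give about 3800 nM, with a range from 1900 nM to 7600 nM. The expected step is a 1.0-fold lower number from compound 2 to compound 3 (0.00 log units; within the scatter), that is, no change beyond the scatter.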

Compound 3, half-maximal cytotoxic concentration: 4350 nM
The estimate for compound 3 lay 1.1-fold (0.06 log units) below the measured number; the range from low to high includes it.
By their numbers in this assay, from the lowest: compounds 2, 3 and 1 (each within the scatter of the next).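

In this assay, tying the isopropyl on the sulfonyl sulfur back into a cyclopropyl ring gives only a small step (a 1.1-fold higher number from compound 2 to compound 3 (0.06 log units; within the scatter)), and replacing the ethyl with cyclopropyl gives another (a 1.1-fold lower number from compound 1 to compound 3 (0.02 log units; within the scatter)). For the compounds shown here, the earlier pair held only open-chain groups on the sulfur, so this is the first sign that a three-membered ring there also leaves the number within the scatter. Ethyl, isopropyl and cyclopropyl on this sulfonyl sulfur therefore cannot be told apart in this read-out, and no measurement offered here explains that result.

As far as these compounds go, all three groups are small and made of carbon alone, so it remains open whether a longer chain, a phenyl ring or an amine at this place would shift the number. The compounds shown also leave open how changes to the shared core would register.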